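Swapping the aminophenyl ketone for an aminothiophene

The source may hold more compounds than are shown below. What is called first, only, known or untested is meant among the compounds shown, and "the series" means these compounds.

Compound 1 `COc1ccc(-c2cc3ccccc3nc2C=O)cc1` is the smallest member of this set. In a functional assay on NCI-H460 cells (Homo sapiens) for antiproliferative activity, read by XTT assay, with a stated time of 72 h (a lower number here means a stronger inhibitor, a higher number a weaker inhibitor), compound 1 gives only a limit, > 10000 nM, and no number. Compound 2 `COc1ccc(-c2cc3ccccc3nc2/C=C/C(=O)c2ccc(N)cc2)cc1` extends the same core through a double-bonded chain to a carbonyl carrying a 4-aminophenyl group; in this assay compound 2 gives 7400 nM. Compound 3 `COc1ccc(-c2cc3ccccc3nc2/C=C/C(=O)c2ccc([N+](=O)[O-])cc2)cc1` carries a nitro group in place of the amino group, and in this assay compound 3 gives 6470 nM. Within the data shown here, the step of a 1.1-fold lower number from compound 2 to compound 3 (0.06 log units; within the scatter) is the only measured step, and it stays within the scatter. Among the measured compounds shown here, compound 2 therefore holds the higher of the two numbers known so far, with compound 3 its nearest neighbour, and the two cannot be told apart.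

Compound 4 `COc1ccc(-c2cc3ccccc3nc2/C=C/C(=O)c2sccc2N)cc1` keeps the chain and the carbonyl of compound 2 but changes the ring attached to them: 3-aminothiophen-2-yl in place of 4-aminophenyl on a carbonyl carbon. For the measured compounds named here, no measured step exchanges one ring for another; the one step that exists, from compound 2 to compound 3, alters only the substituent on the aromatic carbon and moves the number very little. With nothing pointing to a large shift, the expected step of a 1.1-fold lower number from compound 2 to compound 4 (0.02 log units; within the scatter) is none beyond the scatter. Compound 4 is therefore estimated at 7000 nM in this assay, with a range from 2500 nM to 20000 nM.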

Compound 4, half-maximal inhibitory concentration: > 10000 nM
Compound 4 was reported as a limit (the forecaster's own chance of this, stated with the estimate: 25%); middle value at least 1.4-fold (0.15 log units) from the limit.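

Compound 4 gives > 10000 nM in this assay, which is a limit of the assay and not a number. The earlier compounds shown here changed only the substituent on the ring, whereas this exchange of the ring itself on the carbonyl carbon gives an at least 1.3-fold higher number from compound 2 to compound 4 (0.13 log units; that floor lies within the scatter) and an at least 1.5-fold higher number from compound 3 to compound 4 (0.18 log units; that floor lies within the scatter), so 3-aminothiophen-2-yl brings no lower number than either substituted phenyl ring, although both floors lie within the scatter. The true size of the change stays unknown because the reading stops at the limit of the assay: the limit of > 10000 nM in this assay, at which 2 of the 4 values shown sit.

The compounds shown leave open how far above that limit compound 4 lies, and so whether the ring exchange matters at all or only appears to. They also leave open whether the thiophene ring itself or the place of its amino group sets the outcome, which a plain thiophen-2-yl, a 5-aminothiophen-2-yl or a pyridine ring on the same carbonyl carbon could help to separate.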